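The source may report more compounds than this note shows. Statements on the series, on what has been measured and on what is new or still open speak of the compounds shown alone.

Measured compounds in a functional assay on Huh-7 cells (Homo sapiens) for antiproliferative activity, read by sulforhodamine B assay, with a stated time of 72 h; on this read-out lower numbers stand for stronger inhibition and higher numbers for weaker inhibition:
- compound 1 `N#Cc1ccc(COc2ccc(-c3cc(CN4CCN(Cc5ccc(C(F)(F)F)cc5)CC4)no3)cc2)cc1` — 1000 nM
- compound 2 `Fc1ccccc1COc1ccc(-c2cc(CN3CCN(Cc4ccc(C(F)(F)F)cc4)CC3)no2)cc1` — 1500 nM
- compound 3 `N#Cc1cccc(COc2ccc(-c3cc(CN4CCN(c5ccc(F)cc5)CC4)no3)cc2)c1` — 1500 nM

Compound 3 stands level with compound 2 at the digits shown, and its gap to compound 1 also lies within the usual scatter, so the three values cannot be ranked. Among the compounds with values here, the only single-site step among them, a 1.5-fold higher number from compound 1 to compound 2 (0.18 log units; within the scatter), concerns the group carried by the saturated chain carbon bound to the oxygen and does not touch the ring nitrogen. Compound 4 `N#Cc1cccc(COc2ccc(-c3cc(CN4CCN(CC5CCCO5)CC4)no3)cc2)c1` arises from compound 3 by (oxolan-2-yl)methyl in place of 4-fluorophenyl on an amine nitrogen in a ring. Within the data shown here, no measured step bears on this position, so the expected step is set at a 1.3-fold higher number from compound 3 to compound 4 (0.12 log units; within the scatter), within the scatter. Compound 4 is thus estimated at 2000 nM, with a range from 700 nM to 6000 nM.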

Compound 4, half-maximal inhibitory concentration: 4200 nM
For compound 4 the middle estimate is 2.1-fold (0.32 log units) below the measured one; low and high end bracket the measured number.
By their numbers in this assay, from the lowest: compounds 1, 2 and 3 (each within the scatter of the next); then compound 4.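

At the amine nitrogen in the six-membered ring, this is the only step among these compounds that lies beyond the scatter: in this assay, (oxolan-2-yl)methyl in place of 4-fluorophenyl gives a modest loss (a 2.8-fold higher number from compound 3 to compound 4 (0.45 log units; beyond the scatter)). The swap replaces an aromatic ring of carbon only with a five-membered non-aromatic ring holding one hetero atom, so this single step cannot show which part of the change matters. No measurement here offers an explanation. As far as these compounds go, how a cyclohexyl group or an unsubstituted phenyl would read on this nitrogen stays open.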